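The compounds below may be only part of what the source reports. "The series", "measured", "known", "first", "only" and "open" are said of these compounds alone.

The account begins with two compounds of a shared core that have been measured in a functional assay on Jurkat cells (Homo sapiens) for cytotoxicity, read by luminescence and CellTiter-Glo, with a stated time of 3 days; a lower number here means a stronger inhibitor, a higher number a weaker inhibitor. Compound 1 `O=C(Nc1ccc(C(F)(F)F)cc1)c1ccc(Cl)cc1O` gives 670 nM in this assay, and compound 2 `O=C(Nc1cc(C(F)(F)F)cc(C(F)(F)F)c1)c1cc(Cl)c(F)cc1O` gives 730 nM in this assay. Compound 1 stands with the lowest of the two numbers, but the gap to compound 2 lies within the scatter of repeated measurements, so the two numbers alone do not place one compound ahead of the other. Going by the values given here, no pair of measured compounds differs in a single place, so no measured step shows how one change moves the read-out in this assay.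

The step of interest leads from compound 1 to compound 3 `O=C(Nc1ccc(C(F)(F)F)cc1)c1ccc(Br)cc1O`, which has not yet been measured in this assay. The change is bromo in place of chloro on an aromatic carbon. The comparison counts one heavy atom leaving and one entering, with no donor or acceptor involved, and the place stays the same. Among the compounds with values here, with no measured step of this kind to lean on, the step from compound 1 to compound 3 in this assay is expected to stay within the scatter, with no clear direction. Compound 3 is therefore estimated at 600 nM in this assay, with a range of 250 nM to 1400 nM. That expectation corresponds to a step of a 1.1-fold lower number from compound 1 to compound 3 (0.05 log units; within the scatter).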

Compound 3, half-maximal inhibitory concentration: 500 nM
The estimate for compound 3 lay 1.2-fold (0.08 log units) above the measured number; the measured number falls inside the stated range.
By their numbers in this assay, from the lowest: compounds 3, 1 and 2 (each within the scatter of the next).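

In this assay, going by these compounds alone, the step from chloro to bromo is the first change in a single place that can be read for this core: a 1.3-fold lower number from compound 1 to compound 3 (0.13 log units; within the scatter). The step lies within the scatter, so at this place, on an aromatic carbon meta to a hydroxy group and para to a large group, the read-out does not separate these two halogens, something that compound 1 and compound 2 could not show because they differ in more than one place. Nothing measured here bears on what lies behind this result.

The compounds shown leave open whether this place would keep the read-out in the same range with a group other than a halogen, such as an amine, a methoxy group, a nitrile or a carboxylic acid. Within the data shown here, they also leave open how the separate differences between compound 1 and compound 2, including the second trifluoromethyl group and the added fluoro group, each move the read-out, since no single step isolates any one of them.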